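A few compounds are considered here, and "the series" means these few. Any claim that something is new, unique, unknown or untested is made for them only; others in the source may bear on it.

Measured in a physicochemical assay for solubility, using the shake flask method, in simulated intestinal fluid, measured as kinetic solubility, with a stated time of 20 h, at pH 6.5; on this read-out higher numbers stand for higher solubility and lower numbers for lower solubility:
- Compound 1 `Fc1ccc(-c2nc3cnc(Nc4ccc(C(F)(F)F)cn4)cc3[nH]2)cc1F`: >= 50000 nM (a limit of the assay)
- Compound 2 `FC(F)(F)c1ccc(Nc2cc3[nH]c(C4CC4)nc3cn2)nc1`: 123000 nM

In this assay, among the measured compounds shown here, compound 2 gives 123000 nM as the only true number so far. Compound 1 gives >= 50000 nM and this is a limit, not a number. There is therefore nothing to rank compound 2 against.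

Compound 3 (`FC1(F)CCC(c2nc3cnc(Nc4ccc(C(F)(F)F)cn4)cc3[nH]2)CC1`) keeps the shared core of compound 2 but puts 4,4-difluorocyclohexyl in place of cyclopropyl on an aromatic carbon. For the measured compounds named here, the one measured step at that same carbon is a step that the limit leaves unreadable from compound 1 to compound 2 and it offers no usable size, so the data provide no measured guide to the new group.

The expectation is thus a judgement and starts from compound 2 at 123000 nM in this assay, with a modest fall as the likeliest outcome. The expected change is a 2.1-fold lower number from compound 2 to compound 3 (0.31 log units; beyond the scatter) as an estimate, and it is uncertain. Compound 3 may also be reported only as a limit. Compound 3 is estimated at 60000 nM with an expected range of 15000 nM to 150000 nM in this measurement.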

Compound 3, solubility: 93000 nM
Compound 3: middle estimate off by 1.6-fold (0.19 log units), on the low side; the range from low to high includes it.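

In this assay, the carbon between two ring nitrogen atoms now has its first readable step: replacing cyclopropyl with 4,4-difluorocyclohexyl gives a 1.3-fold lower number from compound 2 to compound 3 (0.12 log units; within the scatter). The entering ring has 8 heavy atoms, including 2 fluorine, while the leaving ring has 3 heavy atoms, yet the two numbers cannot be told apart in this pair. This single step therefore shows that a large change in the size of this non-aromatic ring need not bring a readable change in the number, although one pair sets no general rule. The two steps that start from compound 1 cannot be read, because compound 1 is reported only as a limit: the limit of >= 50000 nM in this assay, at which 1 of the 3 values shown sits.

That leaves the comparison between the aromatic 3,4-difluorophenyl and the two non-aromatic rings unresolved, so the compounds shown do not tell whether an aromatic ring at this carbon matters. They also leave open whether a group of a different kind at this carbon, such as an amine or a carboxylic acid, would move the number beyond the usual scatter of the measurement.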